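Working notes: removing the methoxy from compound 2

The compounds below may be only part of what the source reports. "The series", "measured", "known", "first", "only" and "open" are said of these compounds alone.

Among the compounds with values here, the two measured members are compound 1 `CC(=O)/C(=C\c1c(-c2ccccc2)[nH]c2ccccc12)S(=O)(=O)c1ccccc1` and compound 2 `COc1ccc2[nH]c(-c3ccccc3)c(/C=C(\C#N)S(=O)(=O)c3ccccc3)c2c1`. Within the data shown here, in a functional assay on SN12C cells (Homo sapiens) for inhibition, read by sulforhodamine B assay, with a stated time of 48 h (on this read-out higher numbers stand for weaker inhibition of growth and lower numbers for stronger inhibition of growth), compound 1 gives 1900 nM, and compound 2 gives 7800 nM; on these two numbers compound 2 stands highest, with compound 1 as its only neighbour, the gap between them beyond the scatter. Compound 3 `N#C/C(=C\c1c(-c2ccccc2)[nH]c2ccccc12)S(=O)(=O)c1ccccc1` is not yet measured. It differs from compound 2 in one place: hydrogen in place of methoxy on an aromatic carbon. Among the measured compounds shown here, no measured pair isolates this change, so its size is not known from the series. Nothing seen so far forces a move beyond the scatter in either direction, but the lower number of compound 1, 1900 nM, shows where the series can reach. Compound 3 is therefore expected to give 4500 nM in this assay, with a range from 1500 nM to 13000 nM. This estimate corresponds to a 1.7-fold lower number from compound 2 to compound 3 (0.24 log units; within the scatter), a step expected to be modest and toward stronger inhibition.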

Compound 3, concentration for 50% growth inhibition: 5200 nM
Compound 3: the middle estimate sits 1.2-fold (0.06 log units) below what was measured, and the stated range covers the measured number.
By their numbers in this assay, from the lowest: compound 1; then compounds 3 and 2 (each within the scatter of the next).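

In this assay, hydrogen in place of methoxy on this aromatic carbon gives a 1.5-fold lower number from compound 2 to compound 3 (0.18 log units; within the scatter), so the read-out does not separate the two groups at this position on the cyano-bearing scaffold. With compound 3 in hand, the series also has a pair that differs only at the double-bonded chain carbon: cyano in place of acetyl gives a 2.7-fold higher number from compound 1 to compound 3 (0.44 log units; beyond the scatter), and of the two one-place changes shown, only this one lies beyond the scatter. No available measurement accounts for the size of either step.

Still open, as far as these compounds go, is whether a group such as an amine or a carboxylic acid on the same aromatic carbon would move the number beyond the scatter. Also open, from the compounds shown here alone, are a primary amide or a longer ketone chain at the chain carbon, and whether methoxy behaves the same alongside acetyl.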